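Ester Enlargement on a Dihydropyridine Functional Readout

The compounds below may be only part of what the source reports. "The series", "measured", "known", "first", "only" and "open" are said of these compounds alone.

Measured compounds:
compound 1 `CCOC(=O)C1=C(C)N(c2ccc(F)cc2)C=CC1c1ccccc1` gives -42.5% in a functional assay, tested at 200 ug/mL; a lower number here means a stronger effect, a higher number a weaker effect of the compound at the concentration tested
compound 2 `CCOC(=O)C1=C(C)N(c2ccc(Cl)cc2)C=CC1c1ccccc1` gives -37.4% in this assay

Compound 2 stands highest of the two numbers; its nearest neighbour is compound 1, and the step of a number 5.1 percentage points higher from compound 1 to compound 2 (within the scatter) lies within the scatter. Compound 3 `CC1=C(C(=O)OC(C)(C)C)C(c2ccccc2)C=CN1c1ccc(Cl)cc1` differs from compound 2 by tert-butyl in place of ethyl on an oxygen next to a carbonyl group. Among the measured compounds shown here, no measured step touches the ester; the single measured step concerns the aromatic halogen only, so no direction can be drawn from it. Compound 3 is therefore expected to sit near compound 2, with the estimated step of a number 0.4 percentage points higher from compound 2 to compound 3 (within the scatter) carrying wide uncertainty. The estimate for compound 3 is -37%, ranging from -58% to -16%.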

Compound 3, a percentage reported as activity, at one concentration (the size of the read-out at that concentration, not a potency): -48%
The estimate for compound 3 lay 11 percentage points above the measured number; measured number inside the range.
By their numbers in this assay, from the lowest: compounds 3, 1 and 2 (each within the scatter of the next, the first and the last beyond it).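

In (this assay), the ester position responds where the aromatic halogen did not: tert-butyl in place of ethyl gives a modest move toward a stronger effect (a number 10.6 percentage points lower from compound 2 to compound 3 (beyond the scatter)), while the halogen exchange stayed within the scatter (a number 5.1 percentage points higher from compound 1 to compound 2 (within the scatter)). Among the compounds shown here, this single step is the only reading of the ester position so far, and nothing available explains it. From the compounds shown here alone, whether the effect tracks the size of the ester group remains open, as an isopropyl ester, a carboxylic acid or an amide in this place would show. Whether tert-butoxycarbonyl acts the same way alongside the fluoro substituent is also unresolved.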